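Methoxy in place of fluoro: notes on the next step

This account rests on a few compounds, and the source may have more. Where it says the series, first, only, none or still open, it means among the compounds named here.

Compound 1 `COc1ccc(/C=C/c2cc(OC)cc(OC)c2/C=C/C(=O)c2ccc(C(F)(F)F)cc2)cc1` gives 18.7 ug/mL
Compound 2 `COc1ccc(/C=C/c2cc(OC)cc(OC)c2/C=C/C(=O)c2ccc(F)cc2)cc1` gives 12.2 ug/mL

Among the compounds with values here, both values come from a functional assay on HepG2 cells (Homo sapiens) for antiproliferative activity, read by MTT assay, with a stated time of 48 h (a higher number here means a weaker inhibitor, a lower number a stronger inhibitor), and are the only numbers so far in this small series. Compound 2 therefore has a single point of comparison, and the two values lie within the scatter of each other. The measured step is a 1.5-fold lower number from compound 1 to compound 2 (0.19 log units; within the scatter) and does not separate them.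

The next compound is compound 3 `COc1ccc(/C=C/c2cc(OC)cc(OC)c2/C=C/C(=O)c2ccc(OC)cc2)cc1`, which has methoxy in place of fluoro on an aromatic carbon, para to a large group (methoxy in place of fluoro on an aromatic carbon) on an otherwise shared core. Only the measured step above bears on this change, as it concerns the same aromatic carbon. Within the data shown here, it stayed within the scatter, and methoxy has no measured precedent here. No step beyond the scatter is therefore expected in this assay, and no direction can be assigned with confidence.

For compound 3 the expected value is 13 ug/mL in this assay. The estimated range for compound 3 runs from 6.5 ug/mL to 26 ug/mL as a working interval. The expected change is a 1.1-fold higher number from compound 2 to compound 3 (0.03 log units; within the scatter) and would stay within the scatter.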

Compound 3, half-maximal inhibitory concentration: 4.9 ug/mL
Compound 3: middle estimate off by 2.7-fold (0.42 log units), on the high side, and the stated range ends above it.
By their numbers in this assay, from the lowest: compound 3; then compounds 2 and 1 (each within the scatter of the next).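

At this aromatic carbon, the choice of group can move the read-out beyond the scatter in this assay: methoxy in place of fluoro gives a 2.5-fold lower number from compound 2 to compound 3 (0.40 log units; beyond the scatter), a modest step and the first in this series to clear the scatter. Methoxy in place of trifluoromethyl gives a 3.8-fold lower number from compound 1 to compound 3 (0.58 log units; beyond the scatter), also modest, so compound 3 stands apart from both earlier compounds, which remain within the scatter of each other and are not separated by this change. No accompanying measurement on these three compounds speaks to what lies behind these steps.

The compounds shown leave open whether a hydroxy group, an amine or a longer alkoxy chain on this carbon would read like methoxy or like the two fluorine-bearing groups. From the compounds shown here alone, all three compounds share one core and differ at this carbon alone, so it also remains open whether the step from 4-fluorophenyl to 4-methoxyphenyl would hold on another core or in another cell line.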